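The source may hold more compounds than are shown below. What is called first, only, known or untested is meant among the compounds shown, and "the series" means these compounds.

Compound 1 `Oc1nc2nonc2nc1Nc1ccc(OC(F)(F)F)c(Cl)c1`: 3000 nM
Compound 2 `Oc1nc2nonc2nc1Nc1ccc(OCC(F)(F)F)cc1`: 42300 nM
Compound 3 `Oc1nc2nonc2nc1Nc1cccc(S(F)(F)(F)(F)F)c1`: 3700 nM

Three compounds share one core and differ only in the substituted aromatic ring attached through the amine. In an assay on mitochondria from L6 cells (Rattus norvegicus) for activation, with a stated time of 90 min (a lower number here means that less compound is needed, a higher number that more compound is needed for the effect), compound 3 gives 3700 nM, the second highest of the three numbers. Compound 1 gives 3000 nM, and the two values lie within the usual scatter of one another, so no order between them can be read. Compound 2 gives 42300 nM, a far higher number that lies well beyond the scatter.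

Compound 4 `Oc1nc2nonc2nc1Nc1cccc(OC(F)(F)F)c1` has not yet been measured in this assay. It differs from compound 3 in one place: a group of 5 heavy atoms (1 carbon, 1 oxygen, 3 fluorine; no ring) in place of a group of 6 heavy atoms (5 fluorine, 1 sulfur; no ring), on an aromatic carbon. Among the compounds with values here, no pair of measured compounds differs in a single place, so there is no measured step to set the size of this change. Compound 4 is expected to show a modest rise in the number, possibly no more than the scatter, because compound 1 gives 3000 nM with a trifluoromethoxy group on a similar ring. The estimate for compound 4 is 5000 nM, ranging from 1500 nM to 16000 nM. This expected result for compound 4 corresponds to a step of a 1.4-fold higher number from compound 3 to compound 4 (0.13 log units; within the scatter).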

Compound 4, half-maximal effective concentration: 5100 nM
Compound 4: middle estimate off by 1.0-fold (0.01 log units), on the low side, and the stated range covers the measured number.
By their numbers in this assay, from the lowest: compounds 1, 3 and 4 (each within the scatter of the next); then compound 2.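

In this assay, within the data shown here, the step gives the first direct reading of a single change: trifluoromethoxy in place of the group of 6 heavy atoms (5 fluorine, 1 sulfur) on this aromatic carbon yields a 1.4-fold higher number from compound 3 to compound 4 (0.14 log units; within the scatter). The entering group carries 1 hydrogen-bond acceptor and the leaving group carries none, yet the assay does not separate the two at this position, and the exchange is tolerated within the scatter. The data offer no measured property that could account for this result.

From the compounds shown here alone, it remains open whether an amine, a carboxylic acid or a longer chain on this aromatic carbon would also stay within the scatter. The compounds shown also leave open what replacing the hydroxyl group on the shared core would do.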